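This account rests on a few compounds, and the source may have more. Where it says the series, first, only, none or still open, it means among the compounds named here.

Measured so far:
- compound 1 `O=C(NO)c1ccc(CN2C(=O)/C(=C3\Nc4ccccc4\C3=N/O)c3cc(F)ccc32)cc1`: 50 nM
- compound 2 `O=C(/C=C/c1ccc(CN2C(=O)/C(=C3\Nc4ccccc4\C3=N/O)c3cc(F)ccc32)cc1)NO`: 50 nM

In a functional assay on PC-3 cells (Homo sapiens) for cytotoxicity, read by colorimetric assay (on this read-out lower numbers stand for stronger inhibition and higher numbers for weaker inhibition), compound 1 stands level with compound 2 at 50 nM. Within the data shown here, the single measured step, no change at the digits printed from compound 1 to compound 2 (within the scatter), lies within the scatter, but it concerns the hydroxycarbamoyl group and not the group changed next.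

Compound 3 `COc1ccc2c(c1)/C(=C1/Nc3ccccc3/C1=N\O)C(=O)N2Cc1ccc(C(=O)NO)cc1` differs from compound 1 by methoxy in place of fluoro on an aromatic carbon. Among the measured compounds shown here, no measured step covers this change, so its size remains open and the step above offers only indirect guidance. The starting point is therefore compound 1 at 50 nM. No step beyond the scatter is expected in this assay, and no direction can be argued with confidence. The expected result is a 1.2-fold higher number from compound 1 to compound 3 (0.08 log units; within the scatter). For compound 3 the estimated value is 60 nM, with an expected range of 20 nM to 180 nM.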

Compound 3, half-maximal inhibitory concentration: 30 nM
For compound 3 the middle estimate is 2.0-fold (0.30 log units) above the measured one; low and high end bracket the measured number.
By their numbers in this assay, from the lowest: compounds 3, 1 and 2 (each within the scatter of the next).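

In this assay methoxy in place of fluoro on an aromatic carbon gives a 1.7-fold lower number from compound 1 to compound 3 (0.22 log units; within the scatter). Compound 1 and compound 2 spoke only to the hydroxycarbamoyl end, whereas this pair shows that a second site, para to a fused ring and meta to a fused ring, also absorbs a change without a step beyond the scatter, even as the substituent goes from 1 heavy atom to 2 and gains 1 hydrogen-bond acceptor. No supporting measurement bears on this result.

Going by these compounds, whether this position stays as flat for an amine, a carboxylic acid or a longer alkoxy chain remains open. Also open, on these data alone, is whether methoxy behaves the same way alongside the 2-(hydroxycarbamoyl)ethenyl group of compound 2.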